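The compounds below may be only part of what the source reports. "The series", "measured", "known", "first", "only" and "open" are said of these compounds alone.

Measured compounds: compound 1 `Cc1ccsc1CN[C@@H]1C[C@H]2C[C@@H]([C@H]1C)C2(C)C` gives 10000 nM; compound 2 `CCc1csc(CN[C@@H]2C[C@H]3C[C@@H]([C@H]2C)C3(C)C)c1` gives 25000 nM; compound 3 `C=Cc1ccsc1CN[C@@H]1C[C@H]2C[C@@H]([C@H]1C)C2(C)C` gives 50000 nM.

In an ADME assay on MDCK cells (Canis lupus familiaris) for cytotoxicity, read by microscopy, with a stated time of 48 h (a higher number here means that more compound is tolerated, a lower number that less compound is tolerated), compound 3 stands highest of the three numbers; compound 2 lies within the scatter of it, while compound 1 lies beyond the scatter below it, as a 5.0-fold higher number from compound 1 to compound 3 (0.70 log units; beyond the scatter) shows. Compound 4 `C[C@H]1[C@H](NCc2sccc2C2CCCC2)C[C@H]2C[C@@H]1C2(C)C` differs from compound 3 by cyclopentyl in place of vinyl on an aromatic carbon. Going by the values given here, only one measured step changes a group at an aromatic carbon, a 5.0-fold higher number from compound 1 to compound 3 (0.70 log units; beyond the scatter), and it does not test an entering ring. Among the compounds with values here, that step makes a higher number plausible, but a change of this size has no direct precedent here, so the expected step of a 1.4-fold lower number from compound 3 to compound 4 (0.15 log units; within the scatter) is small and uncertain. Compound 4 is estimated at 35000 nM, within 10000 nM to 100000 nM.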

Compound 4, minimum cytotoxic concentration: 12500 nM
Compound 4: middle estimate off by 2.8-fold (0.45 log units), on the high side; measured number inside the range.
By their numbers in this assay, from the lowest: compounds 1, 4, 2 and 3 (each within the scatter of the next, the first and the last beyond it).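

In this assay, cyclopentyl in place of vinyl gives a 4.0-fold lower number from compound 3 to compound 4 (0.60 log units; beyond the scatter), so the one ring tested at this position does not keep what vinyl gained over methyl. Cyclopentyl in place of methyl gives a 1.3-fold higher number from compound 1 to compound 4 (0.10 log units; within the scatter), which leaves these two groups unseparated. The number therefore does not follow group size across methyl, vinyl and cyclopentyl at this position. On these data alone, whether a phenyl or a hydroxymethyl group here would stand with vinyl or with cyclopentyl remains open. Nothing shown gives a reason for the difference between vinyl and cyclopentyl.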